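Formyl for Methyl at the Reporting Limit

A few compounds are considered here, and "the series" means these few. Any claim that something is new, unique, unknown or untested is made for them only; others in the source may bear on it.

Compound 2 `Cc1ccc(OCc2cn(-c3ccc(S(=O)(=O)N4CCc5ccccc5C4)cc3)nn2)cc1` was tested in a functional assay on HuCC-A1 cells (Homo sapiens) for cytotoxicity, read by MTT assay, with a stated time of 48 h; on this read-out higher numbers stand for weaker inhibition and lower numbers for stronger inhibition. In this assay compound 2 reaches only a limit, > 50 ug/mL, not a measured number. Compound 1 `Cc1ccccc1OCc1cn(-c2ccc(S(=O)(=O)N3CCc4ccccc4C3)cc2)nn1` likewise gives only a limit, > 50 ug/mL. Compound 3 `COc1cc2c(cc1OC)CN(S(=O)(=O)c1ccc(-n3cc(COc4ccc([N+](=O)[O-])cc4)nn3)cc1)CC2` also gives only a limit, > 50 ug/mL. The step that the two limits leave unreadable from compound 1 to compound 2 therefore cannot be read. Compound 4 `O=Cc1ccc(OCc2cn(-c3ccc(S(=O)(=O)N4CCc5ccccc5C4)cc3)nn2)cc1` carries the change (formyl in place of methyl on an aromatic carbon). Within the data shown here, no measured step bears on this change with a readable size, since every value shown sits at the limit of > 50 ug/mL in this assay, at which 3 of the 3 values shown sit. No step beyond the scatter can be foreseen in either direction, and the most likely outcome is again a limit. The expected step that the limit leaves unreadable from compound 2 to compound 4 is thus essentially none. Compound 4 is expected near 60 ug/mL, with a range from 25 ug/mL to 150 ug/mL.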

Compound 4, half-maximal inhibitory concentration: > 50 ug/mL
Compound 4 ended at the assay's limit (the forecaster's own chance of this, stated with the estimate: 75%); the middle value is on the limit's open side.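

Compound 4 gives only a limit, like compound 1 and compound 2, so neither new step to compound 4 can be read: the limit of > 50 ug/mL in this assay, at which 4 of the 4 values shown sit.

As far as these compounds go, how formyl and methyl compare in this assay stays open, with no measured number on either side.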